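Lactam in place of pyrazole on the bicyclic core

A few compounds are considered here, and "the series" means these few. Any claim that something is new, unique, unknown or untested is made for them only; others in the source may bear on it.

Three compounds of this series have been run in an ADME assay on microsomes from liver (Homo sapiens) for metabolic stability, read by LC-MS, using NADPH, with stated times of 5 min and 30 min, tested at 1 uM; on this read-out lower numbers stand for slow clearance and higher numbers for fast clearance: compound 1 `Cc1nccn1-c1cnc(NCc2c(F)ccc3c2CCO3)c2cn[nH]c(=O)c12`, compound 2 `Cn1cc(-c2cnc(NCc3c(F)ccc4c3CCO4)c3cn[nH]c(=O)c23)cn1` and compound 3 `O=C1CCCN1c1cnc(NCc2c(F)ccc3c2CCO3)n2cnnc12`. Compound 1 gives 8 mL.min-1.g-1 and compound 2 gives 21 mL.min-1.g-1. For compound 3 the read-out is a limit of the assay, < 3 mL.min-1.g-1. Among the numbers shown, compound 2 stands highest; its nearest neighbour is compound 1, and the single measured step, a 2.6-fold higher number from compound 1 to compound 2 (0.42 log units; beyond the scatter), lies beyond the scatter.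

Compound 4 `O=C1CCCN1c1cnc(NCc2c(F)ccc3c2CCO3)c2cn[nH]c(=O)c12` has not yet been measured. It differs from compound 2 in one place: 2-oxopyrrolidin-1-yl in place of 1-methyl-1H-pyrazol-4-yl on an aromatic carbon. The step of a 2.6-fold higher number from compound 1 to compound 2 (0.42 log units; beyond the scatter) shows that exchanging the group at this position can move the number beyond the scatter. Compound 3, which carries the same 2-oxopyrrolidin-1-yl group on another core, sits at the limit of < 3 mL.min-1.g-1 in this assay, at which 1 of the 3 values shown sits. Taken together, a downward step is expected for compound 4, and of a size beyond the scatter, the expected step being a 3.0-fold lower number from compound 2 to compound 4 (0.48 log units; beyond the scatter). In this assay compound 4 is therefore estimated at 7 mL.min-1.g-1, with a range from 3 mL.min-1.g-1 to 16 mL.min-1.g-1.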

Compound 4, intrinsic clearance in microsomes: 23 mL.min-1.g-1
Beside the measured number, compound 4's estimate is 3.3-fold (0.52 log units) below it; measured number above the stated range.
By their numbers in this assay, from the lowest: compound 1; then compounds 2 and 4 (each within the scatter of the next). At a limit, below all of these: compound 3.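

In this assay, exchanging 1-methyl-1H-pyrazol-4-yl for 2-oxopyrrolidin-1-yl at this position gives a 1.1-fold higher number from compound 2 to compound 4 (0.04 log units; within the scatter), so on this core the non-aromatic ring and the aromatic ring are not told apart by this read-out. The 2-methyl-1H-imidazol-1-yl group is the one that stands apart among the groups shown here, with a 2.9-fold higher number from compound 1 to compound 4 (0.46 log units; beyond the scatter), a separation that until now rested only on a 2.6-fold higher number from compound 1 to compound 2 (0.42 log units; beyond the scatter). The 2-oxopyrrolidin-1-yl group does not bring a low number with it onto this core; compound 3, which carries the group on another core, gives a limit of the assay and not a number: the limit of < 3 mL.min-1.g-1 in this assay, at which 1 of the 4 values shown sits.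

Both 2-oxopyrrolidin-1-yl and 2-methyl-1H-imidazol-1-yl are joined to the core through a ring nitrogen, so that link alone does not account for the separation, and the compounds shown do not tell whether it lies with the imidazole ring or with its methyl group. A plain imidazol-1-yl group or a saturated amine such as morpholine at this position would address that question, and the 2-methyl-1H-imidazol-1-yl group on the core of compound 3 would test how far the core itself sets the number.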